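This account rests on a few compounds, and the source may have more. Where it says the series, first, only, none or still open, it means among the compounds named here.

Compound 1 `Cc1nnc(SCC(=O)N/N=c2/scc(-c3ccc(F)cc3)n2-c2ccccc2)s1` and compound 2 `Cc1ccc(-c2cs/c(=N/NC(=O)CSc3nnnn3-c3ccccc3)n2-c2ccccc2)cc1` share a core and differ from each other in two places. In an ADME assay on NIH3T3 cells (Mus musculus) for cytotoxicity, read by MTT assay, with a stated time of 24 h (on this read-out higher numbers stand for weaker inhibition and lower numbers for stronger inhibition), compound 1 gives 383 ug/mL. For compound 2 this assay reports only a limit, > 500 ug/mL, so compound 2 stands at the edge of the assay rather than at a number (the limit of > 500 ug/mL in this assay, at which 1 of the 2 values shown sits). Compound 3 `O=C(CSc1nnnn1-c1ccccc1)N/N=c1/scc(-c2ccc(F)cc2)n1-c1ccccc1` has not yet been measured; it differs from compound 2 by fluoro in place of methyl on an aromatic carbon. Among the compounds with values here, no pair of measured compounds shows this single change on its own, and compound 1 carries the fluoro group but also differs from compound 2 elsewhere, so the size of the step cannot be read directly. Compound 3 is expected to remain close to where compound 2 sits, with a step of an at least 1.1-fold lower number from compound 2 to compound 3 (0.04 log units; that floor lies within the scatter) in this assay that stays within the usual scatter. The estimate for compound 3 is 450 ug/mL, between 250 ug/mL and 700 ug/mL.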

Compound 3, half-maximal inhibitory concentration: 207 ug/mL
Beside the measured number, compound 3's estimate is 2.2-fold (0.34 log units) above it, outside the stated range (below it).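

In this assay, the change from 4-methylphenyl to 4-fluorophenyl now has a reading of its own, with nothing else altered in the molecule: an at least 2.4-fold lower number from compound 2 to compound 3 (0.38 log units; beyond the scatter). That figure is only a floor, because compound 2 is held at a limit of the assay rather than at a number: the limit of > 500 ug/mL in this assay, at which 1 of the 3 values shown sits.

With the fluoro group kept in place, the other exchange, 1-phenyl-1H-tetrazol-5-yl in place of 5-methyl-1,3,4-thiadiazol-2-yl on the sulfur, gives a 1.9-fold lower number from compound 1 to compound 3 (0.27 log units; within the scatter), so compound 1 and compound 3 cannot be told apart in this assay.

From the compounds shown here alone, it remains open whether a chloro group, a methoxy group or an amine in the same place would act as fluoro does. Also open, going by these compounds, is whether the methyl-to-fluoro step would hold with 5-methyl-1,3,4-thiadiazol-2-yl on the sulfur.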